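The compounds below may be only part of what the source reports. "The series", "measured", "known", "first", "only" and "open" are said of these compounds alone.

Measured so far:
compound 1, `C[C@H]1[C@H](O)[C@@H](CO)O[C@H]1n1cc(Cl)c(N)nc1=O`, > 100 ug/mL
compound 2, `C[C@H]1[C@H](O)[C@@H](CO)O[C@H]1n1cc(Br)c(N)nc1=O`, > 100 ug/mL

Both compounds were tested in a functional assay on NC-37 cells (Homo sapiens) for cytotoxicity; on this read-out lower numbers stand for higher toxicity in this test and higher numbers for lower toxicity in this test. In this assay compound 1 reaches only a limit of the test, > 100 ug/mL. In this assay compound 2 likewise reaches only a limit, > 100 ug/mL. For the measured compounds named here, compound 2 therefore stands at a limit rather than at a number, and the one further value shown is a limit as well, so the step that the two limits leave unreadable from compound 1 to compound 2 cannot be read in size. Going by the values given here, the only evidence on the measured steps is the limit of > 100 ug/mL in this assay, at which 2 of the 2 values shown sit.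

The next compound, compound 3, `C[C@H]1[C@H](O)[C@@H](CO)O[C@H]1n1cc(I)c(N)nc1=O`, differs from compound 2 by iodo in place of bromo on an aromatic carbon. Among the compounds with values here, only the step from compound 1 to compound 2 bears on this change, and its size is hidden by the two limits. Because (the limit of > 100 ug/mL in this assay, at which 2 of the 2 values shown sit), no step beyond the scatter is expected in this assay, in either direction. The step that the limit leaves unreadable from compound 2 to compound 3 is the expected outcome. For compound 3 the estimate in this assay is 150 ug/mL, with a range from 60 ug/mL to 400 ug/mL, and most likely the test again reports only a limit.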

Compound 3, half-maximal cytotoxic concentration: > 100 ug/mL
Compound 3 gave a limit, no number; the forecaster's own chance of this, stated with the estimate: 85%; the middle value is on the limit's open side.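

Compound 3 also reaches only a limit in this assay, > 100 ug/mL. For the compounds shown here, no step from compound 1 or compound 2 to compound 3 can be read in size. The compounds shown leave open whether the chloro, bromo and iodo compounds differ at all in this assay, with no actual number for any of them: the limit of > 100 ug/mL in this assay, at which 3 of the 3 values shown sit.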